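The compounds below may be only part of what the source reports. "The series", "measured", "known", "first", "only" and "open" are said of these compounds alone.

Three compounds have been measured so far in a functional assay on MCF7 cells (Homo sapiens) for cytotoxicity, read by MTT assay, with a stated time of 48 h; a lower number here means a stronger inhibitor, a higher number a weaker inhibitor:

compound 1 `Cc1ccc(/C=C2/S/C(=N/c3ccccc3)N(Cc3ccncc3)C2=O)cc1` gives 36900 nM
compound 2 `O=C1/C(=C\c2ccc(O)cc2)S/C(=N/c2ccccc2)N1Cc1ccncc1` gives 18900 nM
compound 3 `COc1cc(/C=C2/S/C(=N/c3ccccc3)N(Cc3ccncc3)C2=O)ccc1O` gives 28000 nM

Compound 1 has the highest number of the three, but only narrowly: the nearest is compound 3, reached by a 1.3-fold lower number from compound 1 to compound 3 (0.12 log units; within the scatter), and the furthest is compound 2, reached by a 2.0-fold lower number from compound 1 to compound 2 (0.29 log units; within the scatter). Both steps lie within the scatter, so no ranking can be read from them.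

Compound 4 `COc1ccc(OC)c(/C=C2/S/C(=N/c3ccccc3)N(Cc3ccncc3)C2=O)c1` differs from compound 1 in one place: 2,5-dimethoxyphenyl in place of 4-methylphenyl on a double-bonded chain carbon bound to a double-bonded ring carbon. Both measured steps from compound 1 also changed the group on that same double-bonded chain carbon, and neither moved the number beyond the scatter. The expectation for compound 4 is therefore no step beyond the scatter, as a 1.2-fold lower number from compound 1 to compound 4 (0.09 log units; within the scatter). Compound 4 is estimated at 30000 nM, in the range 12000 nM to 75000 nM.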

Compound 4, half-maximal inhibitory concentration: 37000 nM
For compound 4 the middle estimate is 1.2-fold (0.09 log units) below the measured one; the measured number falls inside the stated range.
By their numbers in this assay, from the lowest: compounds 2, 3, 1 and 4 (each within the scatter of the next).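

The 2,5-dimethoxyphenyl group carries hydrogen-bond acceptors that 4-methylphenyl lacks, yet this assay shows a 1.0-fold higher number from compound 1 to compound 4 (0.00 log units; within the scatter). The comparisons with the two hydroxy-bearing groups also stay within the scatter, with a 1.3-fold higher number from compound 3 to compound 4 (0.12 log units; within the scatter) and a 2.0-fold higher number from compound 2 to compound 4 (0.29 log units; within the scatter), so a group with no hydrogen-bond donor at this place is not separated from those with one. No available evidence bears on this result.

As far as these compounds go, all four compounds carry a six-membered aromatic ring of carbon only at this place, so whether an amine or a carboxylic acid on that ring would give a step beyond the scatter remains open. Changes elsewhere on the shared core remain open too.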